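Lengthening the Alkyl Chain of Compound 1

The compounds below may be only part of what the source reports. "The series", "measured", "known", "first", "only" and "open" are said of these compounds alone.

Measured compounds:
- compound 1 `CCCCCCCCOP(=O)(O)OCCSC(=S)N1CCCCC1`: 69000 nM
- compound 2 `CCCCCCCCOP(=O)(O)OCCSC(=S)N1CCCCCC1`: > 100000 nM (a limit of the assay, not a number)

For the measured compounds named here, in an ADME assay on HEK293 cells (Homo sapiens) for inhibition, read by MTT assay, with stated times of 18 h and 4 h (on this read-out higher numbers stand for weaker inhibition and lower numbers for stronger inhibition), compound 1 gives 69000 nM, the only true number available for this series. Compound 2 reaches only a limit of the assay, > 100000 nM. Going by the values given here, that places the limit of > 100000 nM in this assay, at which 1 of the 2 values shown sits, as the sole reference beside compound 1.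

Compound 3 `CCCCCCCCCCCCCCCCOP(=O)(O)OCCSC(=S)N1CCCCC1` has not yet been measured. It differs from compound 1 by octyl in place of hydrogen on a saturated chain carbon, eight bonds along the chain from an oxygen on an unsaturated carbon. Among the compounds with values here, the one measured step, an at least 1.4-fold higher number from compound 1 to compound 2 (0.16 log units; that floor lies within the scatter), replaces piperidin-1-yl with azepan-1-yl on a thiocarbonyl carbon and leaves the chain untouched. Within the data shown here, it therefore gives no direct measure of the size of a chain change, and the data contain no measured step at the chain.

In this assay, a moderate move toward a lower number, meaning stronger inhibition, is tentatively expected, although this direction has little support. The expected change is a 2.8-fold lower number from compound 1 to compound 3 (0.44 log units; beyond the scatter). For compound 3 the estimated value is 25000 nM. The estimated range runs from 5000 nM to 100000 nM.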

Compound 3, half-maximal inhibitory concentration: > 100000 nM
Compound 3: only a limit was reported (the forecaster's own chance of this, stated with the estimate: 15%); at least 4.0-fold (0.60 log units) between middle value and limit.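

In this assay compound 3 gives > 100000 nM, which is a limit of the assay and not a number. Octyl in place of hydrogen on a saturated chain carbon, eight bonds along the chain from an oxygen on an unsaturated carbon, now provides the first step at the chain, an at least 1.4-fold higher number from compound 1 to compound 3 (0.16 log units; that floor lies within the scatter), so the floor of this step does not establish a change in either direction, but the result gives no sign of stronger inhibition from this longer chain. A change at the chain and the earlier change from piperidin-1-yl to azepan-1-yl therefore end alike, leaving compound 1 as the only compound with a true number: the limit of > 100000 nM in this assay, at which 2 of the 3 values shown sit.

On these data alone, how far compound 2 and compound 3 actually lie past that limit remains open, and with it any order between them. Also open, as far as these compounds go, is whether a chain of intermediate length such as dodecyl, or a shorter chain such as butyl, on the core of compound 1 would give a true number and so show how the read-out follows chain length.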